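A Fluorine Added to the Fused Ring of Compound 1

The source may report more compounds than this note shows. Statements on the series, on what has been measured and on what is new or still open speak of the compounds shown alone.

Compound 1 `COc1cc2c(Oc3ccc(NC(=O)c4cc(-c5ccccc5)nc5ccccc45)cc3F)ccnc2cc1OCCCN1CCCCC1` gives 530 nM in a functional assay on HT-29 cells (Homo sapiens) for cytotoxicity, read by MTT assay, with a stated time of 72 h; on this read-out lower numbers stand for stronger inhibition and higher numbers for weaker inhibition.
Compound 2 `COc1cc2c(Oc3ccc(NC(=O)c4cc(-c5cccc(Cl)c5)nc5ccccc45)cc3F)ccnc2cc1OCCCN1CCCCC1` gives 62 nM in this assay.

For the measured compounds named here, compound 1 stands highest of the two numbers measured so far; its nearest neighbour is compound 2, and the step of an 8.5-fold lower number from compound 1 to compound 2 (0.93 log units; beyond the scatter) came with chloro in place of hydrogen on an aromatic carbon of the pendant phenyl ring. Compound 3 `COc1cc2c(Oc3ccc(NC(=O)c4cc(-c5ccccc5)nc5ccc(F)cc45)cc3F)ccnc2cc1OCCCN1CCCCC1` differs from compound 1 by fluoro in place of hydrogen on an aromatic carbon. Going by the values given here, that change sits on the two-ring fused part of the core, not on the pendant ring altered between compound 1 and compound 2, so the single measured step bears on it only loosely: it shows that one added halogen on the amide-bearing side can lower the number a good deal, but at a different place. Among the compounds with values here, no measured step tests the fused ring itself. A modest move toward a lower number is expected, though one that may stay within the scatter. Compound 3 is therefore estimated at 380 nM, with a range from 150 nM to 1000 nM, which corresponds to an expected step of a 1.4-fold lower number from compound 1 to compound 3 (0.14 log units; within the scatter).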

Compound 3, half-maximal inhibitory concentration: 120 nM
For compound 3 the middle estimate is 3.2-fold (0.50 log units) above the measured one; the measured number lies below the stated range.
By their numbers in this assay, from the lowest: compounds 2 and 3 (each within the scatter of the next); then compound 1.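

Fluoro in place of hydrogen on this aromatic carbon of the fused system brings a 4.4-fold lower number from compound 1 to compound 3 (0.65 log units; beyond the scatter) in this assay. For the compounds shown here, until now the only measured step, an 8.5-fold lower number from compound 1 to compound 2 (0.93 log units; beyond the scatter), lay on the pendant phenyl ring, so this result is the first to show that the fused part of the core also responds to a change of a single atom, and that even fluoro, a single heavy atom with no ring and no charge, is enough to move the number beyond the scatter. Nothing available explains why this exchange lowers the number, and no separate measurement bears on it.

The compounds shown carry only fluoro at this place, so it remains open whether a larger or different group, such as an amine, a nitrile or a methoxy group, would lower the number, leave it unchanged or raise it, and whether the other aromatic carbons of that ring would respond in the same way. Also open, on these data alone, is what a compound would give with fluoro on the fused ring and chloro on the pendant ring together, and whether the two changes would add up.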